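Z to E double bonds in the series

The compounds below may be only part of what the source reports. "The series", "measured", "known", "first", "only" and "open" are said of these compounds alone.

Measured in an ADME assay on NIH3T3 cells (Mus musculus) for cytotoxicity, read by WST assay, with a stated time of 72 h; on this read-out lower numbers stand for higher toxicity in this test and higher numbers for lower toxicity in this test:
- compound 1 `CCCCCCCCCCc1c(C)c(CCCCCCCCCC)c2[n+](c1C)CCC2`: 5.08 uM
- compound 2 `CCCCCCCC/C=C\c1c(C)c(/C=C\CCCCCCCC)c2[n+](c1C)CCC2`: 23.5 uM

Of these two, compound 2 holds the higher number at 23.5 uM, and the gap down to compound 1 is beyond the usual scatter.

Compound 3 `CCCCCCCC/C=C/c1c(C)c(/C=C/CCCCCCCC)c2[n+](c1C)CCC2` is the next case, set against compound 2: the two compounds have the same atoms and bonds and differ only in configuration as drawn: 2 of 2 stereo elements differ; a double bond is drawn Z in compound 2 and E in compound 3; a double bond is drawn Z in compound 2 and E in compound 3. Each double bond is drawn Z in compound 2 and E in compound 3, and nothing leaves or enters.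

Among the measured compounds shown here, no measured pair shows a change of this kind, so the size of the step is poorly constrained. For the measured compounds named here, the only lower reference is compound 1 at 5.08 uM, which suggests a slight downward lean in this assay and nothing more. The expected step is a 1.5-fold lower number from compound 2 to compound 3 (0.17 log units; within the scatter), not beyond the scatter. Compound 3 is expected at 16 uM, with an estimated range of 6 uM to 40 uM.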

Compound 3, half-maximal toxic concentration: 4.35 uM
Compound 3: the middle estimate sits 3.7-fold (0.57 log units) above what was measured; the measured number lies below the stated range.
By their numbers in this assay, from the lowest: compounds 3 and 1 (each within the scatter of the next); then compound 2.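

In this assay the double-bond geometry of the two side chains proves to be a variable in its own right, with a 5.4-fold lower number from compound 2 to compound 3 (0.73 log units; beyond the scatter) and no other change to the structures. Compound 2 thus keeps the higher number of this pair, which marks the Z drawing as the one with lower toxicity in this test. Compounds 1 and 2 alone could not isolate configuration, whereas this pair ties the shift to geometry alone: the fact that compounds 2 and 3 differ only in the configuration as drawn.

On these data alone, both double bonds switch together here, so the share of each one taken alone stays open. Also open, as far as these compounds go, is whether the same dependence on geometry holds with a longer chain, or with an amine carried on the chain.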